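Fluoroindazole in place of azaindazole on the triaryl acrylic acid

This account rests on a few compounds, and the source may have more. Where it says the series, first, only, none or still open, it means among the compounds named here.

Of the compounds shown here, three sharing a triaryl acrylic acid core have been measured in a functional assay on MCF7 cells (Homo sapiens) for cytotoxicity, read by CellTiter-Glo, with a stated time of 5 days; on this read-out higher numbers stand for weaker inhibition and lower numbers for stronger inhibition. Compound 1 `CCC/C(=C(/c1ccc(/C=C/C(=O)O)cc1)c1ccc2[nH]ncc2c1)c1ccccc1` gives 11 nM. For the measured compounds named here, compound 2 `O=C(O)/C=C/c1ccc(/C(=C(\c2ccccc2)C2CCCCC2)c2ccc3[nH]ncc3c2)cc1` gives 64 nM; the step of a 5.8-fold higher number from compound 1 to compound 2 (0.76 log units; beyond the scatter) is the only single-point change measured. Compound 3 `CC/C(=C(/c1ccc(/C=C/C(=O)O)cc1)c1cnc2[nH]ncc2c1)c1ccccc1` gives 302 nM, the highest of the three numbers, beyond the scatter from both compound 2 and compound 1.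

Compound 4 `CC/C(=C(/c1ccc(/C=C/C(=O)O)cc1)c1cc(F)c2[nH]ncc2c1)c1ccccc1` has not yet been measured. It differs from compound 3 by a group of 10 heavy atoms (7 carbon, 2 nitrogen, 1 fluorine; one five-membered aromatic ring with 2 hetero atoms, one six-membered aromatic ring of carbon only) in place of a group of 9 heavy atoms (6 carbon, 3 nitrogen; one five-membered aromatic ring with 2 hetero atoms, one six-membered aromatic ring with 1 hetero atom), on a double-bonded chain carbon bound to an aromatic carbon and a double-bonded chain carbon. Going by the values given here, no measured step touches this position: the one known step concerns the chain on the other double-bonded carbon. What the numbers do show is that compound 1, carrying an unsubstituted indazole, sits far lower than compound 3 with its azaindazole, though compound 1 also carries a propyl rather than an ethyl. On that basis the return to an all-carbon six-membered ring in compound 4 is expected to bring a sizeable step downward, estimated as a 12-fold lower number from compound 3 to compound 4 (1.08 log units; beyond the scatter). Compound 4 is therefore estimated at 25 nM, with a range from 8 nM to 80 nM.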

Compound 4, half-maximal inhibitory concentration: 7.5 nM
For compound 4 the middle estimate is 3.3-fold (0.52 log units) above the measured one, outside the stated range (below it).
By their numbers in this assay, from the lowest: compounds 4 and 1 (each within the scatter of the next); then compound 2; then compound 3.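

In this assay, the group on the double-bonded chain carbon bound to an aromatic carbon and a double-bonded chain carbon proves decisive for the number: placing 7-fluoro-1H-indazol-5-yl there gives a 40-fold lower number from compound 3 to compound 4 (1.60 log units; beyond the scatter), the first step measured at this place. The exchange removes a nitrogen from the six-membered aromatic ring and adds a fluorine in a single change, so this step belongs to the two together and cannot be divided between them. Nothing available on the compounds explains the size of the step. Going by these compounds, it remains open how a chlorine or a methoxy group would stand in place of the fluorine. On these data alone, it also remains open whether a step of this size would recur with a propyl or cyclohexyl group in place of the ethyl chain.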